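Removing a Methyl from an Ether Oxygen in a Cytotoxicity Screen

The source may hold more compounds than are shown below. What is called first, only, known or untested is meant among the compounds shown, and "the series" means these compounds.

Compound 1, `C=C1C(=O)O[C@H](C2=C(C)C(O)CC2=O)[C@@H]1CCC(C)=O`: 2%
Compound 2, `C=C1C(=O)O[C@H](C2=C(C)[C@@H](OC)CC2=O)[C@@H]1CCC(C)=O`: 7%

In a functional assay on HaCaT cells (Homo sapiens) for cytotoxicity, read by ELISA and LDH release, with a stated time of 6 h, tested at 5 ug/mL (on this read-out lower numbers stand for a stronger effect and higher numbers for a weaker effect at the one concentration tested), compound 1 gives 2%, and compound 2 gives 7%. Compound 2 carries the higher of the two numbers, yet its gap to compound 1 lies within the scatter, so the two cannot be told apart. Compound 3, `C=C1C(=O)O[C@H](C2=C(C)[C@@H](O)CC2=O)[C@@H]1CCC(C)=O`, differs from compound 2 by hydrogen in place of methyl on an oxygen on a saturated carbon. Going by the values given here, no measured pair shows this change, so no step beyond the scatter is expected in this assay. Compound 3 is expected to sit close to the measured pair, with an expected step of a number 3 percentage points lower from compound 2 to compound 3 (within the scatter). Compound 3 is estimated at 4%, between 0% and 15%.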

Compound 3, a percentage reported as activity, at one concentration (the size of the read-out at that concentration, not a potency): 4%
Beside the measured number, compound 3's estimate shows no gap at the digits printed; the range from low to high includes it.
By their numbers in this assay, from the lowest: compounds 1, 3 and 2 (each within the scatter of the next).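

In this assay the change from methoxy to hydroxy on this saturated ring carbon gives a number 3 percentage points lower from compound 2 to compound 3 (within the scatter) and so leaves the read-out unresolved from that of the methyl ether. Defining the configuration at this carbon also produces no readable difference: the comparison gives a number 2 percentage points higher from compound 1 to compound 3 (within the scatter). That comparison turns on a single structural distinction: the fact that one of compounds 1 and 3 is drawn with a defined configuration and the other without, at the place where they differ.

Going by these compounds, what an amine or an ethoxy group on this carbon would do to the read-out stays open. On these data alone, the effect of the opposite defined configuration at this carbon also stays open.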